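The source may report more compounds than this note shows. Statements on the series, on what has been measured and on what is new or still open speak of the compounds shown alone.

Among the measured compounds shown here, this account follows one structural change starting from compound 1 `CCCN(CC1CCOC1)C(=O)c1cc(OC)c2oc(NCc3cccc(Cl)c3)nc2c1`, the only compound with a number in an ADME assay on Caco-2 cells (Homo sapiens) for permeability, read by LC-MS, in the apical to basolateral direction, with a stated time of 2 h (on this read-out higher numbers stand for higher permeability and lower numbers for lower permeability), where compound 1 gives 246 nm/s. A second compound, compound 2 `COc1cc(C(=O)N2CCC(O)C(C)C2)cc2nc(NCc3cccc(Cl)n3)oc12`, has "not determined" (no result reported) in this assay. Compound 3 `COc1cc(C(=O)N2CC(C)C(O)CC2C2CC2)cc2nc(NCc3cccc(Cl)c3)oc12` is not yet measured; it differs from compound 1 by 2-cyclopropyl-4-hydroxy-5-methylpiperidin-1-yl in place of ((oxolan-3-yl)methyl)(propyl)amino on a carbonyl carbon. The entering group carries 1 hydrogen-bond donor where the leaving group carried 0. For the measured compounds named here, no measured pair shows what such a change does here. The step is expected to be a 1.4-fold lower number from compound 1 to compound 3 (0.16 log units; within the scatter), a modest fall that may sit within the usual scatter. Compound 3 is estimated at 170 nm/s, in the range 80 nm/s to 350 nm/s.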

Compound 3, apparent permeability: 138 nm/s
Beside the measured number, compound 3's estimate is 1.2-fold (0.09 log units) above it, within the range that was stated.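

Putting 2-cyclopropyl-4-hydroxy-5-methylpiperidin-1-yl in place of ((oxolan-3-yl)methyl)(propyl)amino on a carbonyl carbon gives a 1.8-fold lower number from compound 1 to compound 3 (0.25 log units; within the scatter) in this assay. Among the compounds shown here, this is the first readable step at this place, and it shows that a group with 1 hydrogen-bond donor can enter where the leaving group had 0 without a step beyond the scatter.

From the compounds shown here alone, the hydroxy, methyl and cyclopropyl groups arrive together, so their separate contributions stay open, as does the outcome with a plain piperidin-1-yl or a carboxylic acid here. No measurement shown explains the step.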